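The source may report more compounds than this note shows. Statements on the series, on what has been measured and on what is new or still open speak of the compounds shown alone.

Compound 1 `COc1cccc2cc(C(=O)NC3CCCCC3)c(=N)oc12` in an assay on HeLa cells for displacement of a labelled ligand from adenosine receptor A3 (Homo sapiens), read by scintillation counting, with a stated time of 180 min, tested at 10 uM (a higher number here means more inhibition at the concentration tested (going by the name of the read-out), a lower number less inhibition), gives 16%, the higher of the two numbers at hand. Within the data shown here, compound 2 `COc1cccc2cc(C(=O)NCC(O)CO)c(=O)oc12` gives 1% in this assay, a figure that sits beyond the usual scatter below compound 1; as the two compounds differ in more than one place, no single step joins them. Compound 3 `COCCNC(=O)c1cc2cccc(OC)c2oc1=N` has not been measured. It differs from compound 1 by 2-methoxyethyl in place of cyclohexyl on an amide-type nitrogen. Among the measured compounds shown here, with no measured step of this kind to lean on, a modest fall in this assay is expected for compound 3, roughly a number 8 percentage points lower from compound 1 to compound 3 (within the scatter). Compound 3 is estimated at 8%, within -5% to 22%.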

Compound 3, a percentage reported as inhibition, at one concentration (the size of the read-out at that concentration, not a potency): 15%
Compound 3: the middle estimate sits 7 percentage points below what was measured; the range from low to high includes it.
By their numbers in this assay, from the lowest: compound 2; then compounds 3 and 1 (each within the scatter of the next).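

On the amide-type nitrogen, the ring of compound 1 can give way to an open chain without a clear loss: in this assay, 2-methoxyethyl in place of cyclohexyl gives a number 1 percentage points lower from compound 1 to compound 3 (within the scatter). This one change removes the six-membered carbon ring and adds a hydrogen-bond acceptor, yet the number stays within the scatter. Nothing at hand explains this result. Still open, going by these compounds, is whether a longer chain, a terminal amine or a carboxylic acid on this nitrogen would leave the number unchanged or shift it beyond the scatter.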